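The compounds below may be only part of what the source reports. "The series", "measured", "known", "first", "only" and "open" are said of these compounds alone.

Measured so far:
compound 1, `COc1cc2cc(C(=O)NCc3ccc(F)cc3)c(=O)oc2cc1OCCCOc1no[n+]([O-])c1S(=O)(=O)c1ccccc1`, gives 8460 nM in an ADME assay on MCF-10A cells (Homo sapiens) for cytotoxicity, read by MTT assay, with a stated time of 48 h; on this read-out higher numbers stand for weaker inhibition and lower numbers for stronger inhibition;
compound 2, `COc1cc2cc(C(=O)NCCCc3ccccc3)c(=O)oc2cc1OCCCOc1no[n+]([O-])c1S(=O)(=O)c1ccccc1`, gives 5330 nM in this assay.

Within the data shown here, compound 2 has the lower of the two numbers, but its only neighbour is compound 1, and that step, a 1.6-fold lower number from compound 1 to compound 2 (0.20 log units; within the scatter), stays within the scatter. Compound 3, `COc1cc2cc(C(=O)NCCCc3ccc(F)cc3)c(=O)oc2cc1OCCCOc1no[n+]([O-])c1S(=O)(=O)c1ccccc1`, carries the change (fluoro in place of hydrogen on an aromatic carbon). Among the measured compounds shown here, the single measured step from compound 1 to compound 2 moved a chain and a fluoro together and stayed flat, so no movement beyond the scatter is expected here; the estimated step is a 1.0-fold higher number from compound 2 to compound 3 (0.01 log units; within the scatter). For compound 3 the expected value is 5500 nM, within 2800 nM to 11000 nM.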

Compound 3, half-maximal inhibitory concentration: 8920 nM
Estimate against measurement, compound 3: 1.6-fold (0.21 log units) below; low and high end bracket the measured number.
By their numbers in this assay, from the lowest: compounds 2, 1 and 3 (each within the scatter of the next).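

Compound 3 separates the two changes that were mixed in the earlier pair. With only the fluoro added on the aromatic carbon, this assay gives [ a 1.7-fold higher number from compound 2 to compound 3 (0.22 log units; within the scatter) ], and with the fluoro kept and only the chain changed, it gives [ a 1.1-fold higher number from compound 1 to compound 3 (0.02 log units; within the scatter) ], so neither change alone can be told from the scatter. No measured evidence bears on these results. Still open, going by these compounds, is whether a group other than fluoro at this place, such as chloro or methoxy, would give a real step. Also open, on these data alone, is whether an amine on the ring or a longer chain would do so.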